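The compounds below may be only part of what the source reports. "The series", "measured", "known", "first", "only" and "open" are said of these compounds alone.

Compound 2, `COc1cc(-c2nnc3n2NC(c2ccco2)C(C(=O)c2ccc(C(F)(F)F)cc2)S3)cc(OC)c1OC`, was tested in a functional assay on A549 cells (Homo sapiens) for cytotoxicity, read by MTT assay, with a stated time of 48 h (on this read-out lower numbers stand for stronger inhibition and higher numbers for weaker inhibition), where compound 2 gives 37200 nM. Its only companion in the set is compound 1, `COc1cc(-c2nnc3n2NC(c2cccs2)C(C(=O)c2ccccc2)S3)cc(OC)c1OC`, which differs at more than one place; in this assay compound 1 gives 69400 nM. Compound 2 therefore stands at the lower of the two numbers, but the gap to compound 1 lies within the scatter of repeated measurements, so no order between them can be claimed.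

The unmeasured compound 3, `COc1cc(-c2nnc3n2NC(c2ccco2)C(C(=O)c2cccc4ccccc24)S3)cc(OC)c1OC`, is reached from compound 2 by a single change: naphthalen-1-yl in place of 4-(trifluoromethyl)phenyl on a carbonyl carbon. For the measured compounds named here, no step between measured compounds isolates this change, so there is nothing in the set to say how large an effect it should have. On that basis, compound 3 is expected to sit close to compound 2, with a step of a 1.1-fold higher number from compound 2 to compound 3 (0.03 log units; within the scatter) that is unlikely to exceed the scatter in either direction. The estimate for compound 3 in this assay is 40000 nM, with a range from 15000 nM to 110000 nM.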

Compound 3, half-maximal inhibitory concentration: > 100000 nM
Compound 3: only a limit was reported (the forecaster's own chance of this, stated with the estimate: 10%); middle value at least 2.5-fold (0.39 log units) from the limit.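

For the compounds shown here, this is the first step in the set that isolates a single change at this place, a carbonyl carbon: naphthalen-1-yl in place of 4-(trifluoromethyl)phenyl goes with an at least 2.6-fold higher number from compound 2 to compound 3 (0.42 log units; beyond the scatter) in this assay. The group here can therefore shift the read-out beyond the scatter, even though both groups have the same count of heavy atoms and neither has a hydrogen-bond donor, a hydrogen-bond acceptor or a net charge. The size of the step is only a lower bound, as it rests on a limit and not on a number: the limit of > 100000 nM in this assay, at which 1 of the 3 values shown sits.

From the compounds shown here alone, the true distance between the two compounds stays open, as does whether the second aromatic ring or the loss of the trifluoromethyl matters more. Also open, going by these compounds, is what a phenyl ring carrying an amine or a carboxylic acid would give at this place.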